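Chloro to trifluoromethyl: next step in the benzyl ether series

The source may hold more compounds than are shown below. What is called first, only, known or untested is meant among the compounds shown, and "the series" means these compounds.

Compound 1 `CC(=O)c1ccc(OCc2ccccc2C)cc1` gives 77.1 nM in an assay on isolated protein for inhibition of Amine oxidase [flavin-containing] B (Homo sapiens), read by Amplex Red, with a stated time of 15 min; on this read-out higher numbers stand for weaker inhibition and lower numbers for stronger inhibition. For the measured compounds named here, compound 2 `CC(=O)c1ccc(OCc2ccccc2Cl)cc1` gives 311 nM in this assay, the highest of the two numbers measured so far; the one step measured, a 4.0-fold higher number from compound 1 to compound 2 (0.61 log units; beyond the scatter), separates it from compound 1. Compound 3 `CC(=O)c1ccc(OCc2ccccc2C(F)(F)F)cc1` carries trifluoromethyl in place of chloro on an aromatic carbon. Going by the values given here, no measured step involves a trifluoromethyl group, so the only bearing comes from the exchange of methyl for chloro at the same carbon, which moved this assay by a 4.0-fold higher number from compound 1 to compound 2 (0.61 log units; beyond the scatter); that step was modest and beyond the scatter, but it does not settle the direction of a further exchange at this carbon. Compound 3 is therefore expected to sit near the same number or somewhat higher, an estimated step of a 1.3-fold higher number from compound 2 to compound 3 (0.11 log units; within the scatter). The estimate for compound 3 in this assay is 400 nM, with a range from 120 nM to 1300 nM.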

Compound 3, half-maximal inhibitory concentration: 183 nM
Compound 3: middle estimate off by 2.2-fold (0.34 log units), on the high side; the measured number falls inside the stated range.
By their numbers in this assay, from the lowest: compound 1; then compounds 3 and 2 (each within the scatter of the next).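

In this assay, trifluoromethyl in place of chloro on this aromatic carbon gives a 1.7-fold lower number from compound 2 to compound 3 (0.23 log units; within the scatter) and so brings 4 heavy atoms where chloro has 1 without a step that can be told from the scatter. Methyl now stands apart from both other groups, since trifluoromethyl in its place gives a 2.4-fold higher number from compound 1 to compound 3 (0.38 log units; beyond the scatter) and follows the same direction as a 4.0-fold higher number from compound 1 to compound 2 (0.61 log units; beyond the scatter) in the chloro exchange, leaving compound 1 the most potent of the three. No measured evidence accounts for this separation.

The compounds shown leave open whether a methoxy group, an amine or a longer chain on this carbon would match compound 1 or fall with compound 2 and compound 3. They also leave open whether the same order of groups would hold on any other carbon of this ring.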